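The compounds below may be only part of what the source reports. "The series", "measured", "known", "first", "only" and "open" are said of these compounds alone.

Measured so far:
compound 1 `O=C(N/N=C/c1ccc(F)cc1)c1cccnc1Nc1cccc(C(F)(F)F)c1` — 36.5%
compound 2 `O=C(N/N=C/c1cccc(Cl)c1)c1cccnc1Nc1cccc(C(F)(F)F)c1` — 40.4%

In a functional assay on the whole organism (strain Wistar) for inhibition, with Rattus norvegicus as the target, read by paw edema, with a stated time of 4 h, at a dose of 10 mg/kg by the intraperitoneal route (on this read-out higher numbers stand for more inhibition at the one dose given (going by the name of the read-out) and lower numbers for less inhibition), compound 1 gives 36.5% and compound 2 gives 40.4%. Compound 2 holds the higher of the two numbers, but the step of a number 3.9 percentage points higher from compound 1 to compound 2 (within the scatter) lies within the scatter, so the two stand level. Compound 3 `O=C(N/N=C/c1ccc(Cl)cc1)c1cccnc1Nc1cccc(C(F)(F)F)c1` differs from compound 2 by 4-chlorophenyl in place of 3-chlorophenyl on a carbon with a double bond to nitrogen. Within the data shown here, the only measured step exchanges one halophenyl for another on the same carbon and moved nothing beyond scatter; no step bears directly on moving chlorine within the ring. No change beyond the scatter is therefore expected, a number 1.4 percentage points lower from compound 2 to compound 3 (within the scatter). Compound 3 is estimated at 39%, ranging 28% to 50%.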

Compound 3, a percentage reported as inhibition, in the whole organism at one dose (the size of the read-out at that dose, not a potency): 43.7%
Beside the measured number, compound 3's estimate is 4.7 percentage points below it, within the range that was stated.
By their numbers in this assay, from the lowest: compounds 1, 2 and 3 (each within the scatter of the next).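

Moving the chlorine, with 4-chlorophenyl in place of 3-chlorophenyl on the carbon with a double bond to nitrogen, is the first change of ring position alone, and in this assay it gives a number 3.3 percentage points higher from compound 2 to compound 3 (within the scatter). Chloro in place of fluoro on an aromatic carbon, now seen as a single change, gives a number 7.2 percentage points higher from compound 1 to compound 3 (within the scatter), so neither change separates these compounds. No supporting data bear on either step.

Still open, from the compounds shown here alone, is whether an amine or a carboxylic acid on that phenyl ring, in place of the halogen, would move the number beyond the scatter.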